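The compounds below may be only part of what the source reports. "The series", "measured", "known", "first", "only" and "open" are said of these compounds alone.

Among the measured compounds shown here, compound 2 `CN(C)C(=O)c1cc2cnc(Nc3ccc(NC(=O)C4(C(=O)Nc5ccc(O)cc5)CC4)cc3)nc2n1C1CCCC1` gives 94.4% in a functional assay on A549 cells (Homo sapiens) for inhibition, read by CCK-8 assay, with a stated time of 72 h, tested at 10 uM (on this read-out higher numbers stand for more inhibition of growth at the one concentration tested and lower numbers for less inhibition of growth), the higher of the two numbers so far; its nearest neighbour is compound 1 `CN(C)C(=O)c1cc2cnc(Nc3ccc(NC(=O)C4(C(=O)Nc5ccccc5)CC4)cc3)nc2n1C1CCCC1`, which in this assay gives 88.8%, the step being a number 5.6 percentage points higher from compound 1 to compound 2 (within the scatter). Compound 3 `CN(C)C(=O)c1cc2cnc(Nc3ccc(NC(=O)C4(C(=O)Nc5ccc(Cl)cc5)CC4)cc3)nc2n1C1CCCC1` differs from compound 2 by chloro in place of hydroxy on an aromatic carbon. For the measured compounds named here, the one measured step concerns hydroxy against hydrogen, not chloro, and stayed within the scatter, so no step beyond the scatter is expected for compound 3 in this assay: a number 5.4 percentage points lower from compound 2 to compound 3 (within the scatter). For compound 3 the expected value is 89%, with a range of 76% to 97%.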

Compound 3, percent growth inhibition at one concentration: 101%
Beside the measured number, compound 3's estimate is 12 percentage points below it, outside the stated range (above it).
By their numbers in this assay, from the lowest: compounds 1, 2 and 3 (each within the scatter of the next, the first and the last beyond it).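

In this assay, among the compounds shown here, chloro in place of hydrogen gives the first step at this position that clears the scatter: a number 12.2 percentage points higher from compound 1 to compound 3 (beyond the scatter). Chloro in place of hydroxy does not separate, a number 6.6 percentage points higher from compound 2 to compound 3 (within the scatter), so a hydrogen-bond donor at this position is not required for a high reading. Nothing on hand bears on the reason for either step.

Open: how an amine, a methoxy group or a carboxylic acid would read at this position. Going by these compounds, also open: whether the step from hydrogen to chloro holds at concentrations other than the one tested.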